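The source may report more compounds than this note shows. Statements on the series, on what has been measured and on what is new or still open speak of the compounds shown alone.

Measured so far:
- compound 1, `COc1ccc(-c2cc(/C=C/C(=O)c3ccc(N)cc3)[nH]n2)cc1`: 22%
- compound 2, `COc1cc(-c2cc(/C=C/C(=O)c3ccc(Cl)c(Cl)c3)[nH]n2)cc(OC)c1OC`: 63%

Both compounds were tested in a functional assay on Hs-578T cells (Homo sapiens) for cytotoxicity, read by sulforhodamine B assay, with a stated time of 48 h, tested at 10 uM; a higher number here means a weaker effect of the compound at the concentration tested, a lower number a stronger effect. Compound 1 gives 22%, the lowest of the two numbers and therefore the stronger effect; compound 2, with 63%, lies well beyond the usual scatter from it. The two compounds differ in several places at once, so their values alone cannot be tied to any single change.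

Compound 3, `COc1ccc(-c2cc(/C=C/C(=O)c3ccc(N)cc3)[nH]n2)cc1OC`, has not yet been measured. It differs from compound 1 in one place: methoxy in place of hydrogen on an aromatic carbon. Within the data shown here, with no single-change step between measured compounds, the direction of the change in this assay is open; a step of modest size is expected, more likely toward a weaker effect than a stronger one. For compound 3 the estimate in this assay is 32%, with a range of 15% to 55%, which means an expected step of a number 10 percentage points higher from compound 1 to compound 3 (within the scatter).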

Compound 3, a percentage reported as activity, at one concentration (the size of the read-out at that concentration, not a potency): 40%
Beside the measured number, compound 3's estimate is 8 percentage points below it, within the range that was stated.
By their numbers in this assay, from the lowest: compound 1; then compound 3; then compound 2.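

In this assay, the pair gives a clean single-change comparison, with a step of a number 18 percentage points higher from compound 1 to compound 3 (beyond the scatter). Methoxy in place of hydrogen at this aromatic carbon, ortho to a methoxy group and meta to a large group, therefore weakens the effect at the concentration tested, though this rests on one pair and one group. Nothing measured here explains why the number moves.

On these data alone, it remains open whether this weakening belongs to methoxy itself or would come with any group placed on this carbon. A hydroxyl group, a fluorine atom or a longer chain such as ethoxy at the same carbon would tell those two readings apart.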